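The compounds below may be only part of what the source reports. "The series", "measured", "known", "first", "only" and "open" are said of these compounds alone.

Measured compounds in a functional assay on MCF7 cells (Homo sapiens) for antiproliferative activity, read by MTT assay, with a stated time of 72 h; on this read-out lower numbers stand for stronger inhibition and higher numbers for weaker inhibition:
Compound 1, `COc1cc2ncnc(N3CCc4ccccc43)c2cc1NC(=O)/C=C/C(C)C`, gives 6780 nM.
Compound 2, `CC(C)/C=C/C(=O)Nc1cc2c(N3CCc4ccccc43)ncnc2cc1O[C@@H]1CCOC1`, gives 9880 nM.
Compound 3, `COc1cc2ncnc(N3CCCc4ccccc43)c2cc1NC(=O)C=C(C)C`, gives 6870 nM.

Compound 1 and compound 2 share a core and differ in one place: oxolan-3-yl in place of methyl on an oxygen on an aromatic ring. That change produced a 1.5-fold higher number from compound 1 to compound 2 (0.16 log units; within the scatter), so the two values in this assay lie within the scatter of each other and no direction of change can be read from them.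

Compound 3 has the same atoms as compound 1 joined differently; the difference between the two cores is not broken down here. In this assay compound 3 and compound 1 give values that sit within the scatter of each other, and compound 3 is likewise within the scatter of compound 2.

Compound 4, `CC(C)=CC(=O)Nc1cc2c(N3CCCc4ccccc43)ncnc2cc1O[C@@H]1CCOC1`, has not yet been measured. It differs from compound 3 by oxolan-3-yl in place of methyl on an oxygen on an aromatic ring. This is the same change that separates compound 1 from compound 2, made at the same place, on the core of compound 3 instead. Among the measured compounds shown here, since the only measured instance of this change gave a 1.5-fold higher number from compound 1 to compound 2 (0.16 log units; within the scatter), a step of similar size is expected from compound 3 to compound 4 in this assay, namely a 1.4-fold higher number from compound 3 to compound 4 (0.14 log units; within the scatter). On that basis compound 4 is estimated to give 9500 nM in this assay, expected to fall between 4500 nM and 20000 nM.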

Compound 4, half-maximal inhibitory concentration: 11100 nM
For compound 4 the middle estimate is 1.2-fold (0.07 log units) below the measured one; the range from low to high includes it.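

In this assay the replacement of methoxy by (oxolan-3-yl)oxy on the core of compound 3 gave a 1.6-fold higher number from compound 3 to compound 4 (0.21 log units; within the scatter) and so, like the earlier step on the core of compound 1, gives no direction of change. The change therefore behaves alike on the two cores shown, with neither step separable from the scatter and no sign that the core alters its outcome in this read-out. This does not show that the change has any effect of its own on antiproliferative activity, and two cores offer no rule for any other core in the series, though the two steps themselves agree closely: the same change on two cores in this assay, a 1.5-fold higher number (0.16 log units; within the scatter) from compound 1 to compound 2 and a 1.6-fold higher number (0.21 log units; within the scatter) from compound 3 to compound 4, 1.1-fold (0.04 log units) apart, within the scatter of two such steps.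

The compounds shown leave open whether the same tolerance would hold for other groups on that oxygen, such as an ethyl group, a longer chain, or a chain ending in an amine, and whether the other stereoisomer of the oxolan-3-yl group would fall in the same range. They also leave open whether a change to this oxygen substituent would show up at all on a core giving stronger inhibition, where a step might be easier to tell from the scatter.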